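Shortening One Side Chain of Compound 2

The source may hold more compounds than are shown below. What is called first, only, known or untested is meant among the compounds shown, and "the series" means these compounds.

Compound 1, `CC(C)=CCC/C(C)=C/C(=O)NC(=N)NC(=O)/C=C(\C)CCC=C(C)C`: 38900 nM
Compound 2, `CC(C)=CCC/C(C)=C/CC/C(C)=C/C(=O)NC(=N)NC(=O)/C=C(\C)CC/C=C(\C)CCC=C(C)C`: 9200 nM

In a functional assay on U-373MG ATCC cells for inhibition, with U373 MG (Homo sapiens) as the target, read by MTT assay, with a stated time of 72 h (a lower number here means a stronger inhibitor of growth, a higher number a weaker inhibitor of growth), compound 1 gives 38900 nM and compound 2 gives 9200 nM, so compound 2 stands at the lower of the two numbers, beyond the scatter from compound 1. Compound 3, `CC(C)=CCC/C(C)=C/CC/C(C)=C/C(=O)NC(=N)NC(=O)/C=C(\C)CCC=C(C)C`, keeps the longer side of compound 2 but on the other side carries hydrogen in place of 3-methylbut-2-en-1-yl on a saturated chain carbon bound to a double-bonded chain carbon, so that side now matches compound 1. Going by the values given here, no step of this kind has been measured, so a moderate upward move in this assay is expected, roughly half-way toward compound 1. Compound 3 is therefore estimated at 18000 nM, with a range from 8000 nM to 45000 nM, a step of a 2.0-fold higher number from compound 2 to compound 3 (0.29 log units; within the scatter).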

Compound 3, concentration for 50% growth inhibition: 35000 nM
The estimate for compound 3 lay 1.9-fold (0.29 log units) below the measured number, and the stated range covers the measured number.
By their numbers in this assay, from the lowest: compound 2; then compounds 3 and 1 (each within the scatter of the next).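

In this assay, hydrogen in place of 3-methylbut-2-en-1-yl gives a 3.8-fold higher number from compound 2 to compound 3 (0.58 log units; beyond the scatter), so this group counts when the other side chain is already long. Added instead to compound 1, the same group gives a 1.1-fold lower number from compound 1 to compound 3 (0.05 log units; within the scatter), so among these compounds the longer chain on one side alone does not separate compound 3 from compound 1, and only compound 2, long on both sides, stands apart. Nothing available explains this dependence on the other side chain. From the compounds shown here alone, whether a longer chain on both sides, or a carboxylic acid in place of 3-methylbut-2-en-1-yl, would move the number remains open.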